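Aryl replacement on a fused core in melanoma cell inhibition

The source may hold more compounds than are shown below. What is called first, only, known or untested is meant among the compounds shown, and "the series" means these compounds.

Measured compounds:
Compound 1, `COc1cc(-c2cc3nccc(-c4cc(OC)c(OC)c(OC)c4)n3n2)cc(OC)c1OC`: > 10000 nM
Compound 2, `COc1cc(-c2ccnc3cc(-c4cn(CO)c5ccccc45)nn23)cc(OC)c1OC`: 93 nM
Compound 3, `COc1cc(-c2ccnc3cc(-c4ccc(C)c(C)c4)nn23)cc(OC)c1OC`: 391 nM

In a functional assay on B16-F0 cells (Mus musculus) for inhibition, read by CCK-8 assay, with a stated time of 48 h (on this read-out higher numbers stand for weaker inhibition and lower numbers for stronger inhibition), compound 1 reaches only a limit of the assay, > 10000 nM. Compound 3 stands highest of the two numbers recorded; compound 2 gives a lower number, and the gap between compound 2 and compound 3 lies beyond the usual scatter. Compound 4, `COc1cc(-c2ccnc3cc(-c4ccc(C(C)=O)cc4)nn23)cc(OC)c1OC`, differs from compound 3 in one place: 4-acetylphenyl in place of 3,4-dimethylphenyl on an aromatic carbon. For the measured compounds named here, no measured pair shows such a change, so nothing anchors its size; the step of a 1.0-fold higher number from compound 3 to compound 4 (0.01 log units; within the scatter) is expected to stay within the scatter, with no clear direction. Compound 4 is therefore expected to give 400 nM in this assay, with a range from 120 nM to 1500 nM.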

Compound 4, half-maximal inhibitory concentration: 3930 nM
Beside the measured number, compound 4's estimate is 9.8-fold (0.99 log units) below it, and the stated range ends below it.
By their numbers in this assay, from the lowest: compound 2; then compound 3; then compound 4. At a limit, above all of these: compound 1.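

In this assay, the aryl group on this aromatic carbon of the five-membered ring matters: 4-acetylphenyl in place of 3,4-dimethylphenyl gives a 10-fold higher number from compound 3 to compound 4 (1.00 log units; beyond the scatter). For the compounds shown here, this pair gives the size of such a change at this position, which the earlier compounds could not show. The entering group brings a carbonyl and one hydrogen-bond acceptor, but nothing measured here accounts for the step.

This single pair cannot separate removing the two methyl groups from adding the acetyl group. On these data alone, how a phenyl ring carrying an amine or a carboxylic acid would fare at this carbon remains open.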